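The source may report more compounds than this note shows. Statements on the series, on what has been measured and on what is new or still open speak of the compounds shown alone.

Notes on the series, an ADME assay on microsomes from liver (Homo sapiens) for metabolic stability, with a stated time of 10 min; a lower number here means that less of the compound is left, a higher number that more of the compound is left:
compound 1 `COCCCc1cc(-c2ccc(Cl)cc2)n(-c2ccccc2OC)n1`: 58%
compound 2 `COc1ccccc1-n1nc(C2CCOC(C)(C)C2)cc1-c1ccc(Cl)cc1`: 98%

Compound 2 stands highest of the two. The measured difference is a number 40 percentage points higher from compound 1 to compound 2 (beyond the scatter), a large step beyond the scatter, with 2,2-dimethyloxan-4-yl in place of 3-methoxypropyl on an aromatic carbon. Compound 3 `COc1ccccc1-n1nc(C2C[C@H](C)O[C@@H](C)C2)cc1-c1ccc(Cl)cc1` differs from compound 2 as follows: 2,6-dimethyloxan-4-yl in place of 2,2-dimethyloxan-4-yl on an aromatic carbon. In short, 2,6-dimethyloxan-4-yl takes the place of 2,2-dimethyloxan-4-yl on an aromatic carbon. Going by the values given here, the one measured step bears on this only loosely, as no measured pair compares two dimethyloxanyl groups. With compound 2 at 98%, little room remains for a rise, so a small fall or no change beyond the scatter is expected in this assay. The estimated change is a number 8 percentage points lower from compound 2 to compound 3 (within the scatter). For compound 3 the expected value is 90%, with an estimated range of 72% to 100%.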

Compound 3, percent of the compound remaining: 40%
Compound 3: the middle estimate sits 50 percentage points above what was measured, and the stated range ends above it.
By their numbers in this assay, from the lowest: compound 3; then compound 1; then compound 2.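

In this assay, 2,6-dimethyloxan-4-yl in place of 2,2-dimethyloxan-4-yl gives a number 58 percentage points lower from compound 2 to compound 3 (beyond the scatter), although the two groups hold the same atoms, joined differently, so the composition of the group at this position does not settle the result. A dimethyloxanyl ring here therefore does not by itself give a high number: against the open 3-methoxypropyl chain, the 2,6-dimethyloxan-4-yl group gives a number 18 percentage points lower from compound 1 to compound 3 (beyond the scatter), whereas 2,2-dimethyloxan-4-yl stood higher than that chain. No data at hand account for this gap between the two isomeric groups.

From the compounds shown here alone, it remains open how the other stereoisomer of 2,6-dimethyloxan-4-yl would compare with compound 3. Also open, going by these compounds, is where a plain oxan-4-yl group, without methyl groups, or a piperidine ring carrying a ring amine would fall at this position.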